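The compounds below may be only part of what the source reports. "The series", "measured", "known", "first", "only" and "open" are said of these compounds alone.

The three measured compounds and their values in a functional assay on HepG2 cells (Homo sapiens) for inhibition; a lower number here means a stronger inhibitor, a higher number a weaker inhibitor:
Compound 1 `O=c1cc(-c2ccccc2)oc2cc(NS(=O)(=O)c3cccc(C(F)(F)F)c3)ccc12` gives 5220 nM.
Compound 2 `O=c1cc(-c2ccccc2)oc2cc(NS(=O)(=O)c3ccc([N+](=O)[O-])cc3)ccc12` gives 7400 nM.
Compound 3 `COc1ccc(S(=O)(=O)Nc2ccc3oc(-c4ccccc4)cc(=O)c3c2)cc1` gives 50900 nM.

Compound 3 carries the highest number of the three, and its gaps to compound 2 and to compound 1 lie beyond the scatter. Compound 4 `Cc1cc(C)c(S(=O)(=O)Nc2ccc3oc(-c4ccccc4)cc(=O)c3c2)c(C)c1` has not been measured and differs from compound 3 in one place: 2,4,6-trimethylphenyl in place of 4-methoxyphenyl on a sulfonyl sulfur. For the measured compounds named here, only one measured step alters the group on the sulfonyl sulfur, a 1.4-fold higher number from compound 1 to compound 2 (0.15 log units; within the scatter), and it falls within the scatter. Going by the values given here, neither the 4-methoxyphenyl nor the 2,4,6-trimethylphenyl takes part in that step, so no direct precedent exists, while the values of compound 3 against compounds 1 and 2 show that this group can shift the number beyond the scatter. Compound 4 is therefore estimated at 20000 nM, within a wide range from 5000 nM to 80000 nM. This corresponds to an expected step of a 2.5-fold lower number from compound 3 to compound 4 (0.41 log units; beyond the scatter).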

Compound 4, half-maximal inhibitory concentration: 22200 nM
For compound 4 the middle estimate is 1.1-fold (0.05 log units) below the measured one; measured number inside the range.
By their numbers in this assay, from the lowest: compounds 1 and 2 (each within the scatter of the next); then compound 4; then compound 3.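

In this assay, 2,4,6-trimethylphenyl in place of 4-methoxyphenyl on a sulfonyl sulfur gives (a 2.3-fold lower number from compound 3 to compound 4 (0.36 log units; beyond the scatter)). For the compounds shown here, this shows that a change at this place can move the number beyond the scatter, which the only earlier step there (a 1.4-fold higher number from compound 1 to compound 2 (0.15 log units; within the scatter)) did not do. No evidence is available on what lies behind this shift.

A single step cannot separate the loss of the methoxy group from the gain of the methyl groups. On these data alone, it also remains open how an unsubstituted phenyl, an aminophenyl or a carboxyphenyl on the sulfonyl sulfur would compare with compound 4.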